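A few compounds are considered here, and "the series" means these few. Any claim that something is new, unique, unknown or untested is made for them only; others in the source may bear on it.

Measured so far in a functional assay on HepG2 cells (Homo sapiens) for antiproliferative activity, with a stated time of 72 h; on this read-out lower numbers stand for an effect already at smaller amounts and higher numbers for an effect only at larger amounts of compound:
Compound 1 `COc1ccc(-c2cc(=O)c3c(OC)cc(OC)cc3n2S(=O)(=O)c2ccc(C=O)cc2)cc1` gives > 34400 nM, which is a limit of the assay.
Compound 2 `COc1ccc(-c2cc(=O)c3c(OC)cc(OC)cc3n2S(=O)(=O)c2ccc(C)c([N+](=O)[O-])c2)cc1` gives > 51700 nM, which is a limit of the assay.
Compound 3 `COc1ccc(-c2cc(=O)c3c(OC)cc(OC)cc3n2S(=O)(=O)c2cc(F)c(F)c(F)c2)cc1` gives > 65500 nM, which is a limit of the assay.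

Compound 3 therefore stands at a limit only, and the other two values are limits as well (the limit of > 34400 nM in this assay, at which 1 of the 3 values shown sits, (the limit of > 51700 nM in this assay, at which 1 of the 3 values shown sits), (the limit of > 65500 nM in this assay, at which 1 of the 3 values shown sits)). Compound 4 `COc1ccc(-c2cc(=O)c3c(OC)cc(OC)cc3n2S(=O)(=O)c2ccc(Cl)cc2)cc1` differs from it by 4-chlorophenyl in place of 3,4,5-trifluorophenyl on a sulfonyl sulfur. The two changes already made at the same sulfonyl sulfur, a step that the two limits leave unreadable from compound 1 to compound 3 and a step that the two limits leave unreadable from compound 2 to compound 3, bear on this change; both leave their size unreadable, so no direction beyond the scatter can be drawn from them for this assay. Compound 4 is expected to sit at a limit again, with an estimated step of an at least 1.3-fold lower number from compound 3 to compound 4 (0.11 log units; that floor lies within the scatter). The estimate for compound 4 is 50000 nM, between 20000 nM and 100000 nM.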

Compound 4, half-maximal effective concentration: > 34400 nM
Compound 4 was reported as a limit; the forecaster's own chance of this, stated with the estimate: 85%; the middle value lies beyond the limit too.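

In this assay, among the compounds shown here, compound 4 gives > 34400 nM, a limit, and compound 1, compound 2 and compound 3 are limits too, so no step among them can be read. Going by these compounds, whether any group on the sulfonyl sulfur changes the read-out stays open.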